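The source may report more compounds than this note shows. Statements on the series, on what has been measured and on what is new or still open speak of the compounds shown alone.

Working notes on a four-compound series. Compound 1 `Oc1cccc(-c2cc(-c3ccccc3)cc(-c3cccs3)n2)c1` carries a thiophen-2-yl group; in a functional assay on HCT-15 cells (Homo sapiens) for cytotoxicity, read by ELISA, with a stated time of 2 days (a higher number here means a weaker inhibitor, a lower number a stronger inhibitor), compound 1 gives 10900 nM. Compound 2 `Oc1cccc(-c2cc(-c3ccccc3)cc(-c3ccsc3)n2)c1` differs from it by thiophen-3-yl in place of thiophen-2-yl on an aromatic carbon; in this assay compound 2 gives 7660 nM, and the step is a 1.4-fold lower number from compound 1 to compound 2 (0.15 log units; within the scatter). Compound 3 `Oc1cccc(-c2cc(-c3ccccc3)nc(-c3cccs3)c2)c1` has a different core; the difference between the two cores is not broken down here. In this assay compound 3 gives 14100 nM, which sits within the scatter of both compound 1 and compound 2. Compound 4 `Oc1cccc(-c2cc(-c3ccccc3)nc(-c3ccsc3)c2)c1` differs from compound 3 by thiophen-3-yl in place of thiophen-2-yl on an aromatic carbon, the same change as that made from compound 1 to compound 2. For compound 4 a step of a 1.3-fold lower number from compound 3 to compound 4 (0.11 log units; within the scatter) in this assay is expected, because the earlier step of a 1.4-fold lower number from compound 1 to compound 2 (0.15 log units; within the scatter) stayed within the scatter. Compound 4 is therefore estimated at 11000 nM, with a range from 5500 nM to 22000 nM.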

Compound 4, half-maximal inhibitory concentration: 24600 nM
Estimate against measurement, compound 4: 2.2-fold (0.35 log units) below; measured number outside the range, above it.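

In this assay, thiophen-3-yl in place of thiophen-2-yl gives a 1.7-fold higher number from compound 3 to compound 4 (0.24 log units; within the scatter). Set beside the same change on the core of compound 1, the steps do not separate the two cores: the same change on two cores in this assay, a 1.4-fold lower number (0.15 log units; within the scatter) from compound 1 to compound 2 and a 1.7-fold higher number (0.24 log units; within the scatter) from compound 3 to compound 4, 2.5-fold (0.39 log units) apart, within the scatter of two such steps. On these two cores the change stays within the scatter, which is all that carries over; it does not show that the cores respond differently, nor does it give a reliable direction for the step on either core.

Open, from the compounds shown here alone, is whether any group at this place moves the number beyond the scatter on either core. An amine or a carboxylic acid in place of the thiophene ring would be one such test.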